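Replacing 4-nitrobenzyl with 3-phenylprop-2-en-1-yl on the shared core

A few compounds are considered here, and "the series" means these few. Any claim that something is new, unique, unknown or untested is made for them only; others in the source may bear on it.

In a functional assay on Caco-2 cells (Homo sapiens) for inhibition, read by MTT assay, with a stated time of 48 h, tested at 10 uM (a higher number here means more inhibition of growth at the concentration tested, a lower number less inhibition of growth), compound 1 `Cc1cc(=O)c2c(O)cc(OCc3ccccc3)c([C@H]3CCN(C)C[C@H]3O)c2o1` gives 18%, compound 2 `Cc1cc(=O)c2c(O)cc(OCc3ccc(Br)cc3)c([C@H]3CCN(C)C[C@H]3O)c2o1` gives 13% and compound 3 `Cc1cc(=O)c2c(O)cc(OCc3ccc([N+](=O)[O-])cc3)c([C@H]3CCN(C)C[C@H]3O)c2o1` gives 14%, so compound 3 stands within the scatter of both others. Compound 4 `Cc1cc(=O)c2c(O)cc(OC/C=C/c3ccccc3)c([C@H]3CCN(C)C[C@H]3O)c2o1` differs from compound 3 by 2-phenylethenyl in place of 4-nitrophenyl on a saturated chain carbon bound to an oxygen on an aromatic ring, which is 2-phenylethenyl in place of 4-nitrophenyl on a saturated chain carbon bound to an oxygen on an aromatic ring. The nearest evidence is a number 4 percentage points lower from compound 1 to compound 3 (within the scatter), a number 1 percentage points higher from compound 2 to compound 3 (within the scatter) and a number 5 percentage points lower from compound 1 to compound 2 (within the scatter), all within the scatter. None of these alters the chain itself, so the evidence is indirect, and no step beyond the scatter is expected. The estimated change is a number 2 percentage points higher from compound 3 to compound 4 (within the scatter). For compound 4, the expected value is 16%, with an estimated range of 5% to 30%.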

Compound 4, percent growth inhibition at one concentration: 9%
For compound 4 the middle estimate is 7 percentage points above the measured one; low and high end bracket the measured number.
By their numbers in this assay, from the lowest: compounds 4, 2, 3 and 1 (each within the scatter of the next).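

In this assay, among these compounds, this is the first change to the chain itself rather than to a substituent on the aromatic ring, and it also stays within the scatter: a number 5 percentage points lower from compound 3 to compound 4 (within the scatter), a number 4 percentage points lower from compound 2 to compound 4 (within the scatter) and a number 9 percentage points lower from compound 1 to compound 4 (within the scatter). Across these compounds, then, 2-phenylethenyl in place of an aryl group on this saturated chain carbon gives no step that can be read as a real difference. Nothing available explains these numbers. What the compounds shown leave open is whether an amine, a carboxylic acid or a longer chain at this position would give a step beyond the scatter.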